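This account rests on a few compounds, and the source may have more. Where it says the series, first, only, none or still open, it means among the compounds named here.

Measured so far:
Compound 1, `CCS(=O)(=O)Nc1ccc(Oc2ccccc2)c(-c2cn(C)c(=O)c3[nH]ccc23)c1`, in an ADME assay on microsomes from liver (Rattus norvegicus) for metabolic stability, read by HPLC, using NADPH, with stated times of 5 min and 60 min, tested at 10 uM; a higher number here means faster removal of the compound, a lower number slower removal: 3330 mL/min/kg
Compound 2, `CCS(=O)(=O)Nc1ccc(Oc2ccc(C(F)(F)F)cc2)c(-c2cn(C)c(=O)c3[nH]ccc23)c1`, in this assay: 583 mL/min/kg

Compound 2 stands at the lower of the two numbers obtained so far; compound 1 sits above it. For the measured compounds named here, the one step between them is a 5.7-fold lower number from compound 1 to compound 2 (0.76 log units; beyond the scatter). In that step a trifluoromethyl group stands in place of a hydrogen on an aromatic carbon.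

Compound 3, `CCS(=O)(=O)Nc1ccc(OCC(C)(C)C)c(-c2cn(C)c(=O)c3[nH]ccc23)c1`, has not yet been measured. It differs from compound 2 in one place: neopentyl in place of 4-(trifluoromethyl)phenyl on an oxygen on an aromatic ring. Going by the values given here, only the step from compound 1 to compound 2 bears on this change, and only partly, since the trifluoromethyl group that lowered the number in that step leaves together with its whole ring, while a branched five-carbon chain without a ring enters. With compound 1 giving 3330 mL/min/kg and compound 2 giving 583 mL/min/kg, the expected direction is upward, by an amount estimated as a 2.6-fold higher number from compound 2 to compound 3 (0.41 log units; beyond the scatter). For compound 3 the estimate in this assay is therefore 1500 mL/min/kg, with a range from 500 mL/min/kg to 4500 mL/min/kg.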

Compound 3, clearance: 433 mL/min/kg
Compound 3: the middle estimate sits 3.5-fold (0.54 log units) above what was measured; measured number below the stated range.
By their numbers in this assay, from the lowest: compounds 3 and 2 (each within the scatter of the next); then compound 1.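

In this assay two very different groups on this oxygen cannot be told apart, since a 1.3-fold lower number from compound 2 to compound 3 (0.13 log units; within the scatter) is a step that stays within the usual scatter, even though a neopentyl chain with no ring takes the place of the larger 4-(trifluoromethyl)phenyl. An aromatic ring at this position is therefore not required for a number in the range of compound 2, and among these three compounds it is the plain phenyl of compound 1 that stands apart, as a 7.7-fold lower number from compound 1 to compound 3 (0.89 log units; beyond the scatter) is a step beyond the scatter, like the step to compound 2. No independent measurement is available to explain why a trifluoromethyl-bearing ring and a branched chain give such similar numbers here.

On these data alone, whether a shorter chain such as ethyl, a saturated ring such as cyclohexyl, or a chain ending in an amine or a carboxylic acid would give a number in the same range remains open. Also open, as far as these compounds go, is which part of compound 1 is actually lost in this test, and whether that part changes in compound 2 and compound 3.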